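Swapping an Acyclic Amide Substituent for a Hydroxyazetidine

This account rests on a few compounds, and the source may have more. Where it says the series, first, only, none or still open, it means among the compounds named here.

In an ADME assay on the whole organism (strain CD1) for pharmacokinetics, with Mus musculus as the target, read by LC-MS, at a dose of 5 mg/kg by the intravenous route (on this read-out lower numbers stand for narrower distribution and higher numbers for wider distribution into tissues), two close relatives of a shared core have been measured. Compound 1, `Cc1c(Oc2cnc(C(=O)NCCO)cn2)ccc2c1B(O)OC2`, gives 0.636 L/kg. For the measured compounds named here, compound 2, `CCC[C@H](CO)NC(=O)c1cnc(Oc2ccc3c(c2C)B(O)OC3)cn1`, gives 0.874 L/kg, which is the higher of the two numbers, though the only step that separates them, a 1.4-fold higher number from compound 1 to compound 2 (0.14 log units; within the scatter), is within the scatter, so no order between the two can be claimed.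

Compound 3, `Cc1c(Oc2cnc(C(=O)N3CC(C)(O)C3)cn2)ccc2c1B(O)OC2`, differs from compound 2 at the amide end of the molecule: 3-hydroxy-3-methylazetidin-1-yl in place of (1-(hydroxymethyl)butyl)amino on a carbonyl carbon. Going by the values given here, the single measured step, the propyl in place of hydrogen on a saturated chain carbon from compound 1 to compound 2, touches the same region and produced no movement beyond the scatter. Among the compounds with values here, the change to compound 3 is larger in kind, closing the chain into a four-membered ring and removing one hydrogen-bond donor, but nothing among the measured compounds shows such a ring change, so the estimate rests on the narrow spread seen so far.

Compound 3 is therefore expected to show a 1.2-fold lower number from compound 2 to compound 3 (0.10 log units; within the scatter), and its value in this assay is estimated at 0.7 L/kg, within a range of 0.4 L/kg to 1.25 L/kg.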

Compound 3, volume of distribution at steady state: 0.888 L/kg
Estimate against measurement, compound 3: 1.3-fold (0.10 log units) below; the measured number falls inside the stated range.
By their numbers in this assay, from the lowest: compounds 1, 2 and 3 (each within the scatter of the next).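

In this assay, the ring at this place, the first among the compounds shown, brings a 1.0-fold higher number from compound 2 to compound 3 (0.01 log units; within the scatter) when 3-hydroxy-3-methylazetidin-1-yl takes the place of (1-(hydroxymethyl)butyl)amino on a carbonyl carbon, and a 1.4-fold higher number from compound 1 to compound 3 (0.14 log units; within the scatter) when it takes the place of (2-hydroxyethyl)amino. Earlier, only a change within an open chain had been seen here, whereas these steps show that a four-membered non-aromatic ring, with 1 hydrogen-bond donor in place of 2 and no defined stereocentre, can stand on this carbonyl carbon without a shift beyond the scatter, so the three substituents cannot be told apart on this read-out. Nothing available explains why the number holds across these changes.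

On these data alone, all three compounds carry a hydroxyl group on the amide substituent and share the same core, so it remains open whether an amine, a carboxylic acid or a plain alkyl chain without the hydroxyl at this place would move the number beyond the scatter. As far as these compounds go, it is also open whether a larger ring, such as a piperidine, would behave as the hydroxyazetidine does.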